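A few compounds are considered here, and "the series" means these few. Any claim that something is new, unique, unknown or untested is made for them only; others in the source may bear on it.

Of the compounds shown here, three of one shared core have been measured in a functional assay (trachea) with Rattus norvegicus as the target; on this read-out lower numbers stand for lower potency and higher numbers for higher potency (the scale is a negative logarithm). Compound 1, `CC1(C)C=C(n2ccccc2=O)c2ccccc2O1`, carries only a hydrogen at the varied position and gives 5.05. Compound 2, `CC1(C)C=C(n2ccccc2=O)c2cc(C(=N)NO)ccc2O1`, gives 5.51. Compound 3, `Cc1ccc(C)n1-c1ccc2c(c1)C(n1ccccc1=O)=CC(C)(C)O2`, gives 6.78, the highest of the three numbers; its lead over compound 2 is a number 1.27 log units higher from compound 2 to compound 3 (beyond the scatter) and over compound 1 is a number 1.73 log units higher from compound 1 to compound 3 (beyond the scatter), both beyond the scatter.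

Compound 4, `CC1(C)C=C(n2ccccc2=O)c2cc(C(F)(F)F)ccc2O1`, has not yet been measured. It differs from compound 3 in one place: trifluoromethyl in place of 2,5-dimethyl-1H-pyrrol-1-yl on an aromatic carbon. Among the compounds with values here, the steps that bear on this change are the two that put the 2,5-dimethyl-1H-pyrrol-1-yl group in: a number 1.73 log units higher from compound 1 to compound 3 (beyond the scatter) and a number 1.27 log units higher from compound 2 to compound 3 (beyond the scatter). Within the data shown here, removing that group is therefore expected to cost potency, while the only other step at this position, a number 0.46 log units higher from compound 1 to compound 2 (beyond the scatter), shows that a group of four heavy atoms in place of hydrogen gave a modest gain. Compound 4 is thus expected to land between compound 1 and compound 3, with a step of a number 0.98 log units lower from compound 3 to compound 4 (beyond the scatter) expected in this assay. The estimate for compound 4 is 5.8, in a range from 5.2 to 6.5.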

Compound 4, logarithm of the reciprocal of the active concentration, log(1/C): 7.37
Estimate against measurement, compound 4: 1.57 log units below, and the stated range ends below it.
By their numbers in this assay, from the lowest: compound 1; then compound 2; then compound 3; then compound 4.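

In this assay, the highest number at this aromatic carbon does not need the five-membered aromatic ring of the 2,5-dimethyl-1H-pyrrol-1-yl group: trifluoromethyl, with no ring and fewer heavy atoms, gives a further gain (a number 0.59 log units higher from compound 3 to compound 4 (beyond the scatter)) and the largest step over the unsubstituted compound (a number 2.32 log units higher from compound 1 to compound 4 (beyond the scatter)). The number of heavy atoms alone does not set the outcome, since the group in compound 2 and trifluoromethyl have the same count and differ in their atoms, yet the change between them is large (a number 1.86 log units higher from compound 2 to compound 4 (beyond the scatter)). No measurement is available that explains why trifluoromethyl ranks above the other groups at this position.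

The compounds shown leave open whether a single chlorine atom, a nitrile or a methyl group on this carbon would stay close to trifluoromethyl or fall back toward hydrogen, which would show how much of the gain is specific to the three fluorine atoms. They also leave open how a carboxylic acid or an amine would fare here, and whether the order of these four compounds would hold in any other read-out.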